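The source may report more compounds than this note shows. Statements on the series, on what has been measured and on what is new or still open speak of the compounds shown alone.

In a functional assay on MDA-MB-231 cells (Homo sapiens) for antiproliferative activity, read by MTT assay, with a stated time of 24 h (a lower number here means a stronger inhibitor, a higher number a weaker inhibitor), compound 2 `CCCCc1oc2ccccc2c1C(=O)c1ccc(OCCCC(=O)N2CCOCC2)cc1` gives 31600 nM, within the scatter of compound 1 `CCCCc1oc2ccccc2c1C(=O)c1ccc(OCCCC(=O)N2CCCC2)cc1`, which gives 48700 nM. Compound 3 `CCCCc1oc2ccccc2c1C(=O)c1ccc(OCCCC(=O)N(C)Cc2ccccc2)cc1` carries a new amide group: benzyl(methyl)amino in place of morpholin-4-yl on a carbonyl carbon. Going by the values given here, only one measured step bears on this change, a 1.5-fold lower number from compound 1 to compound 2 (0.19 log units; within the scatter), which was made on the same carbonyl carbon and stayed within the scatter. Among the compounds with values here, no measured compound carries benzyl(methyl)amino, so the direction is open, and no step beyond the scatter is expected in this assay. The estimated step is a 1.1-fold lower number from compound 2 to compound 3 (0.02 log units; within the scatter). Compound 3 is expected at 30000 nM, within an estimated range of 11000 nM to 75000 nM.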

Compound 3, half-maximal inhibitory concentration: > 50000 nM
Compound 3: a limit, no number; the forecaster's own chance of this, stated with the estimate: 15%; middle value at least 1.6-fold (0.22 log units) away from the limit.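

In this assay compound 3 gives > 50000 nM, a limit and not a number. The change reads as an at least 1.5-fold higher number from compound 2 to compound 3 (0.19 log units; that floor lies within the scatter), and as an at least 1.0-fold higher number from compound 1 to compound 3 (0.01 log units; that floor lies within the scatter), so on this carbonyl carbon the benzyl(methyl)amino group with its aromatic ring gave no move towards a stronger inhibitor, though neither floor shows a change beyond the scatter. The real size of both steps stays unread, and the one fact at hand is this: the limit of > 50000 nM in this assay, at which 1 of the 3 values shown sits.

From the compounds shown here alone, whether a piperazine with a free amine or a simple dimethylamino group on this carbonyl carbon would give a clearly lower number remains open. So does the effect of a carboxylic acid in place of the amide, or of a shorter chain to the ring oxygen.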